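This account rests on a few compounds, and the source may have more. Where it says the series, first, only, none or still open, it means among the compounds named here.

In an assay on cells for inhibition of histone deacetylase 8 (Homo sapiens), read by fluorescence, with a stated time of 30 min (a lower number here means a stronger inhibitor, a higher number a weaker inhibitor), three close relatives of one shared core have been examined. Compound 1 `O=C1NC(=O)/C(=C\c2ccc(OCC(=O)N3N=C(c4ccccc4)CC3c3ccc(F)cc3)cc2)S1` gives 26000 nM. Compound 2 `O=C1NC(=O)/C(=C\c2ccc(OCC(=O)N3N=C(c4ccccc4)CC3c3ccc(F)cc3F)cc2)S1` gives 34000 nM. Compound 3 `Cc1ccc(C2CC(c3ccccc3)=NN2C(=O)COc2ccc(/C=C3/SC(=O)NC3=O)cc2)cc1` gives 31000 nM. Among these three numbers compound 3 carries the second highest; its nearest neighbour is compound 2 and its furthest is compound 1, and neither gap leaves the scatter. The steps between them confirm that picture: a 1.3-fold higher number from compound 1 to compound 2 (0.12 log units; within the scatter) and a 1.2-fold higher number from compound 1 to compound 3 (0.08 log units; within the scatter) both fall within the scatter, as does a 1.1-fold lower number from compound 2 to compound 3 (0.04 log units; within the scatter).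

Compound 4 `O=C1NC(=O)/C(=C\c2ccc(OCC(=O)N3N=C(c4ccccc4)CC3c3ccc(Cl)c(Cl)c3)cc2)S1` is the next member. Its change against compound 3 is 3,4-dichlorophenyl in place of 4-methylphenyl on a saturated ring carbon. Going by the values given here, the one measured step that bears on this place is the exchange of the aryl group on the saturated ring carbon, and that step, a 1.1-fold lower number from compound 2 to compound 3 (0.04 log units; within the scatter), stayed within the scatter; the change of a fluoro for a hydrogen on an aromatic carbon, a 1.3-fold higher number from compound 1 to compound 2 (0.12 log units; within the scatter), likewise stayed within it. Nothing observed here suggests that another aryl group on the same carbon should behave differently. Compound 4 is therefore expected to show a 1.0-fold lower number from compound 3 to compound 4 (0.01 log units; within the scatter), that is, no step beyond the scatter. The estimated value for compound 4 in this assay is 30000 nM, with a range from 12000 nM to 75000 nM.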

Compound 4, half-maximal inhibitory concentration: 10000 nM
Estimate against measurement, compound 4: 3.0-fold (0.48 log units) above; the measured number lies below the stated range.
By their numbers in this assay, from the lowest: compound 4; then compounds 1, 3 and 2 (each within the scatter of the next).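

Until now, swapping the aryl group on the saturated ring carbon had produced nothing beyond the scatter, but in this assay 3,4-dichlorophenyl separates from all three earlier groups, with a 3.1-fold lower number from compound 3 to compound 4 (0.49 log units; beyond the scatter), a 3.4-fold lower number from compound 2 to compound 4 (0.53 log units; beyond the scatter) and a 2.6-fold lower number from compound 1 to compound 4 (0.41 log units; beyond the scatter). This position is therefore not indifferent to the aryl group it carries: 4-fluorophenyl, 2,4-difluorophenyl and 4-methylphenyl remain within the scatter of one another, while compound 4 is the strongest inhibitor of the four, although each of its steps is only modest. The data offer no measurement that accounts for this difference.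

The compounds shown leave open whether both chlorines are needed, since 3-chlorophenyl and 4-chlorophenyl would show whether either chlorine alone gives the same step, and 3,4-dimethylphenyl would show whether the same pattern holds with methyl groups in place of the chlorines. Also open, going by these compounds, is whether the step would carry over to other cores, as the phenyl group on the other ring carbon is the same in all four compounds, and a 4-chlorophenyl or pyridyl group there remains untested alongside 3,4-dichlorophenyl.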